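The source may hold more compounds than are shown below. What is called first, only, known or untested is meant among the compounds shown, and "the series" means these compounds.

Working notes on the series. In a functional assay on A549 cells (Homo sapiens) for antiproliferative activity, read by CCK-8 assay, with a stated time of 72 h (on this read-out higher numbers stand for weaker inhibition and lower numbers for stronger inhibition), compound 1 `COc1ccccc1C(=O)Nc1cccc(-c2oc3cc(-c4ccc(F)cc4)ccc3c(=O)c2O)c1` gives 11700 nM, compound 2 `Cc1ccccc1C(=O)Nc1cccc(-c2oc3cc(-c4ccc(F)cc4)ccc3c(=O)c2O)c1` gives 17600 nM, and compound 3 `CCc1ccc(C(=O)Nc2cccc(-c3oc4cc(-c5ccc(F)cc5)ccc4c(=O)c3O)c2)cc1` gives 18500 nM. The number for compound 3 is the largest of the three, but every step to it lies within the scatter: a 1.6-fold higher number from compound 1 to compound 3 (0.20 log units; within the scatter) and a 1.1-fold higher number from compound 2 to compound 3 (0.02 log units; within the scatter), as does a 1.5-fold higher number from compound 1 to compound 2 (0.18 log units; within the scatter) between the other two. All three varied only the aryl group on the carbonyl carbon, with no step beyond the scatter.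

Compound 4 `O=C(Nc1cccc(-c2oc3cc(-c4ccc(F)cc4)ccc3c(=O)c2O)c1)c1ccc(Br)cc1F` is not yet measured. It differs from compound 3 by 4-bromo-2-fluorophenyl in place of 4-ethylphenyl on a carbonyl carbon. Among the compounds with values here, the steps that bear on it are those changing the same aryl group, from compound 1 and compound 2 to compound 3, and both were within the scatter; no measured step covers a halogenated aryl at this place. In this assay no step beyond the scatter is therefore expected for compound 4: the step is estimated as a 1.2-fold lower number from compound 3 to compound 4 (0.06 log units; within the scatter). Compound 4 is expected to give about 16000 nM, in the range 7000 nM to 40000 nM.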

Compound 4, half-maximal inhibitory concentration: 46100 nM
Estimate against measurement, compound 4: 2.9-fold (0.46 log units) below; the whole stated range lies below it.
By their numbers in this assay, from the lowest: compounds 1, 2 and 3 (each within the scatter of the next); then compound 4.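

In this assay the aryl group on the carbonyl carbon now matters, which compound 1, compound 2 and compound 3 did not show among themselves. With 4-bromo-2-fluorophenyl the number rises, with a 2.5-fold higher number from compound 3 to compound 4 (0.40 log units; beyond the scatter) against 4-ethylphenyl, a 2.6-fold higher number from compound 2 to compound 4 (0.42 log units; beyond the scatter) against 2-methylphenyl and a 3.9-fold higher number from compound 1 to compound 4 (0.60 log units; beyond the scatter) against 2-methoxyphenyl, so all three steps point towards weaker inhibition, each modest in size. No measurement at hand accounts for this shift.

Going by these compounds, the bromine and the fluorine entered together, so it stays open whether one of them alone would give the same step or whether the pair is needed. Also open, on these data alone, is how this position responds to an aryl group carrying an amine or a carboxylic acid, or to a longer alkyl chain in place of the ethyl of compound 3.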